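Moving a chlorine on the outer ring of compound 3

The source may report more compounds than this note shows. Statements on the series, on what has been measured and on what is new or still open speak of the compounds shown alone.

Compound 3 `Cc1c(O)c(=O)ccn1CC(=O)N/N=C1\C(=O)N(CC(=O)Nc2ccccc2Cl)c2ccccc21` was tested in a functional assay on MCF7 cells (Homo sapiens) for cytotoxicity, read by MTT assay, with a stated time of 48 h (on this read-out lower numbers stand for an effect already at smaller amounts and higher numbers for an effect only at larger amounts of compound), and gave 46400 nM. Two close relatives share its core: compound 1 `Cc1ccc(NC(=O)CN2C(=O)/C(=N\NC(=O)Cn3ccc(=O)c(O)c3C)c3ccccc32)cc1` gives 52200 nM, and compound 2 `Cc1c(O)c(=O)ccn1CC(=O)N/N=C1\C(=O)N(CC(=O)Nc2ccccc2)c2ccccc21` gives 48400 nM. On these numbers compound 3 sits at the low end, but its gaps to compound 2 and to compound 1 are both within the usual scatter, so the three cannot be told apart.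

Compound 4 `Cc1c(O)c(=O)ccn1CC(=O)N/N=C1\C(=O)N(CC(=O)Nc2cccc(Cl)c2)c2ccccc21` has the same atoms as compound 3 joined differently: 3-chlorophenyl in place of 2-chlorophenyl on an amide-type nitrogen. Going by the values given here, the steps that bear on this are the ones that alter the same outer ring. From compound 1 to compound 3 a 2-chlorophenyl replaced a 4-methylphenyl and gave a 1.1-fold lower number from compound 1 to compound 3 (0.05 log units; within the scatter); from compound 2 to compound 3 a chloro replaced a hydrogen and gave a 1.0-fold lower number from compound 2 to compound 3 (0.02 log units; within the scatter). Neither change to this ring shifted the number beyond the scatter, so moving the chlorine within the same ring is expected to give no step beyond the scatter either, and compound 4 is estimated at a 1.0-fold lower number from compound 3 to compound 4 (0.00 log units; within the scatter).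

Compound 4 is therefore expected to give about 46000 nM in this assay, within a range from 25000 nM to 90000 nM.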

Compound 4, half-maximal effective concentration: 34600 nM
Beside the measured number, compound 4's estimate is 1.3-fold (0.12 log units) above it; low and high end bracket the measured number.
By their numbers in this assay, from the lowest: compounds 4, 3, 2 and 1 (each within the scatter of the next).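

Moving the chlorine gives in this assay a 1.3-fold lower number from compound 3 to compound 4 (0.13 log units; within the scatter) and so offers the first direct look at where the chlorine sits on this outer ring: 3-chlorophenyl and 2-chlorophenyl on the amide-type nitrogen cannot be told apart. The same holds when the 3-chlorophenyl compound is set against the plain phenyl, with chloro in place of hydrogen giving a 1.4-fold lower number from compound 2 to compound 4 (0.15 log units; within the scatter) and against the 4-methylphenyl, which gives a 1.5-fold lower number from compound 1 to compound 4 (0.18 log units; within the scatter) and leaves all four outer rings shown so far without a difference beyond the scatter. Nothing measured alongside these compounds offers an explanation for these small steps.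

Still open, going by these compounds, is whether a group of another kind on this ring, such as an amine or a carboxylic acid, would shift the number beyond the scatter. Also open is whether a longer chain in place of the ((3-chlorophenyl)carbamoyl)methyl group would do so, given that every compound shown keeps the same link to the shared core.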